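This account rests on a few compounds, and the source may have more. Where it says the series, first, only, none or still open, it means among the compounds named here.

The measured compounds and their values:

compound 1 `CC1CCN(c2c(S(=O)(=O)c3ccc(F)c(Cl)c3)cnc3cc(Cl)ccc23)CC1` gives 94%
compound 2 `CC1CCN(c2c(S(=O)(=O)c3ccccc3)cnc3cc(Cl)ccc23)CC1` gives 93%
compound 3 `CC1CCN(c2c(S(=O)(=O)c3cc(F)cc(F)c3)cnc3cc(Cl)ccc23)CC1` gives 94%

All three were tested in an assay on isolated protein for displacement of a labelled ligand from metabotropic glutamate receptor 5 (Homo sapiens), with a stated time of 60 min, tested at 1 uM; on this read-out lower numbers stand for less inhibition and higher numbers for more inhibition at the one concentration tested (going by the name of the read-out). On this read-out compound 3 sits level with compound 1 at the digits printed, the two of them together the highest of the three numbers; its nearest neighbour is compound 1, with no change at the digits printed between them, and its furthest is compound 2, which lies a single percentage point lower, a gap within the scatter. The three values are thus indistinguishable from one another.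

Compound 4 `COc1ccc(S(=O)(=O)c2cnc3cc(Cl)ccc3c2N2CCC(C)CC2)cc1OC` has not yet been measured. It differs from compound 3 in one place: 3,4-dimethoxyphenyl in place of 3,5-difluorophenyl on a sulfonyl sulfur.

Going by the values given here, three measured steps bear on this change, each a swap of the aryl group on the sulfonyl sulfur: a number 1 percentage points lower from compound 1 to compound 2 (within the scatter); no change at the digits printed from compound 1 to compound 3 (within the scatter); and a number 1 percentage points higher from compound 2 to compound 3 (within the scatter). None of them moved the read-out beyond the scatter, whether the group carried no substituent, one chlorine and one fluorine, or two fluorines. Among the compounds with values here, the 3,4-dimethoxyphenyl group brings two hydrogen-bond acceptors that no measured analogue carries, so the comparison is less direct, but nothing in the data points to a loss. The step from compound 3 to compound 4 is therefore expected to be a number 4 percentage points lower from compound 3 to compound 4 (within the scatter), with no change beyond the scatter. Compound 4 is estimated at 90%, in the range 76% to 97%.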

Compound 4, a percentage reported as inhibition, at one concentration (the size of the read-out at that concentration, not a potency): 93%
Estimate against measurement, compound 4: 3 percentage points below; the measured number falls inside the stated range.
By their numbers in this assay, from the lowest: compounds 2, 4, 1 and 3 (each within the scatter of the next).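

Against every earlier compound in this assay the 3,4-dimethoxyphenyl group on the sulfonyl sulfur leaves the read-out in place: the swaps give a number 1 percentage points lower from compound 3 to compound 4 (within the scatter) and no change at the digits printed from compound 2 to compound 4 (within the scatter) and a number 1 percentage points lower from compound 1 to compound 4 (within the scatter) across the set. Going by these compounds alone, the earlier aryl groups carried only hydrogen or halogen, with 0 hydrogen-bond acceptors, so this is the first sign that a group with 2 hydrogen-bond acceptors, and with oxygen attached to its ring, can stand at this position without a step beyond the scatter. No supporting measurement is available to say why the read-out stays level across these four aryl groups.

As far as these compounds go, all four compounds lie close together near the top of the percentage scale at a single concentration, so any difference among them in potency remains open. Also open, from the compounds shown here alone, is how the read-out would respond to a primary amine or a carboxylic acid on the aryl ring, or to a straight alkyl chain in place of the aryl group on the sulfonyl sulfur.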